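A few compounds are considered here, and "the series" means these few. Any claim that something is new, unique, unknown or untested is made for them only; others in the source may bear on it.

Compound 1 `CC(=O)N1CCC(Sc2c[nH]c3ccc(Cl)cc23)CC1` and compound 2 `CCCC(=O)N1CCC(Sc2c[nH]c3ccc(Cl)cc23)CC1` share a core and differ only at the carbon chain on the carbonyl. In a functional assay on the whole organism with Mus musculus as the target, in the writhing test (a higher number here means that more compound is needed for the effect, a lower number that less compound is needed), compound 1 gives 2.9 mg/kg, while compound 2 gives 8.9 mg/kg; the change is a 3.1-fold higher number from compound 1 to compound 2 (0.49 log units; beyond the scatter). For the measured compounds named here, compound 2 therefore has the higher of the two numbers, and its only neighbour is compound 1.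

Compound 3 `Clc1ccc2[nH]cc(SC3CCN(Cc4ccccc4)CC3)c2c1` arises from compound 2 by benzyl in place of propylcarbonyl on an amine nitrogen in a ring. Going by the values given here, no measured step bears directly on this change: the one known step alters the chain on the carbonyl, whereas here the carbonyl itself leaves and a benzyl takes its place on the amine nitrogen in the ring. Among the compounds with values here, that single step shows only that a larger group at this position gave a modestly higher number. On this basis compound 3 is expected to lie near compound 2, with a step of a 1.1-fold higher number from compound 2 to compound 3 (0.05 log units; within the scatter) that is not beyond the scatter, though with wide uncertainty. The estimate for compound 3 in this assay is 10 mg/kg, within a range from 3 mg/kg to 35 mg/kg.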

Compound 3, dose for half-maximal effect: 9.7 mg/kg
Compound 3: middle estimate off by 1.0-fold (0.01 log units), on the high side, and the stated range covers the measured number.
By their numbers in this assay, from the lowest: compound 1; then compounds 2 and 3 (each within the scatter of the next).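

In this assay the amine nitrogen in the ring keeps its number even when the carbonyl is gone: exchanging propylcarbonyl for benzyl gives a 1.1-fold higher number from compound 2 to compound 3 (0.04 log units; within the scatter) and so does not separate the two groups, although benzyl brings an aromatic ring and no carbonyl. For the compounds shown here, the same benzyl measured against acetyl gives a 3.3-fold higher number from compound 1 to compound 3 (0.52 log units; beyond the scatter) and leaves compound 1 with the lowest number of the three, so a carbonyl on this nitrogen is not needed for a number in this range, and acetyl remains the one group that stands apart. Nothing available here accounts for these numbers.

The compounds shown leave open how a free ring amine, a simple methyl or a sulfonyl group would behave on this nitrogen. They also leave open whether a fluorine or methoxy on the benzyl ring would shift the number.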